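This account rests on a few compounds, and the source may have more. Where it says the series, first, only, none or still open, it means among the compounds named here.

Three compounds share one core and differ only in the group attached to an aromatic nitrogen of a five-membered ring. Compound 1 `CN(CCNCc1cn(-c2cccc(Cl)c2)nn1)CCNc1ccnc2cc(Cl)ccc12` carries 3-chlorophenyl there, and in a functional assay on HCC827 cells (Homo sapiens) for antiproliferative activity, read by sulforhodamine B assay, with a stated time of 72 h (a higher number here means a weaker inhibitor, a lower number a stronger inhibitor), compound 1 gives 9400 nM. Compound 2 `CN(CCNCc1cn(-c2ccc(Br)cc2)nn1)CCNc1ccnc2cc(Cl)ccc12` carries 4-bromophenyl; in this assay compound 2 gives 11000 nM, and the step of a 1.2-fold higher number from compound 1 to compound 2 (0.07 log units; within the scatter) shows that these two lie within the scatter of each other. Compound 3 `CN(CCNCc1cn(C(C)(C)C)nn1)CCNc1ccnc2cc(Cl)ccc12` carries tert-butyl; in this assay compound 3 gives 56000 nM, the highest of the three numbers and so the weakest inhibitor among them. The steps of a 6.0-fold higher number from compound 1 to compound 3 (0.78 log units; beyond the scatter) and a 5.1-fold higher number from compound 2 to compound 3 (0.71 log units; beyond the scatter) both show that exchanging an aromatic group for tert-butyl raised the number by a modest amount.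

Compound 4 `CN(CCNCc1cn(-c2nc3ccccc3[nH]2)nn1)CCNc1ccnc2cc(Cl)ccc12` makes the change (1H-benzimidazol-2-yl in place of tert-butyl on an aromatic nitrogen). The entering group is aromatic, as are the groups of compounds 1 and 2, and it brings one hydrogen-bond donor and one hydrogen-bond acceptor. The two steps above bear on this change in reverse: moving away from tert-butyl lowered the number by a modest amount both times. A step of similar size in the same direction is therefore expected, toward a lower number in this assay, roughly undoing the rise seen in a 5.1-fold higher number from compound 2 to compound 3 (0.71 log units; beyond the scatter). For compound 4 the expected step in this assay is a 4.7-fold lower number from compound 3 to compound 4 (0.67 log units; beyond the scatter). For compound 4 the estimate in this assay is 12000 nM, with a range from 4000 nM to 40000 nM.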

Compound 4, half-maximal inhibitory concentration: 32000 nM
Compound 4: the middle estimate sits 2.7-fold (0.43 log units) below what was measured; low and high end bracket the measured number.
By their numbers in this assay, from the lowest: compounds 1 and 2 (each within the scatter of the next); then compounds 4 and 3 (each within the scatter of the next).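

In this assay, being aromatic is not enough on its own to lower the number at this position: 1H-benzimidazol-2-yl is aromatic, yet the two compounds in the step (a 1.8-fold lower number from compound 3 to compound 4 (0.24 log units; within the scatter)) cannot be told apart. Both halogen-bearing phenyl groups give lower numbers than 1H-benzimidazol-2-yl, as the steps (a 2.9-fold higher number from compound 2 to compound 4 (0.46 log units; beyond the scatter)) and (a 3.4-fold higher number from compound 1 to compound 4 (0.53 log units; beyond the scatter)) show, so the earlier link between an aromatic group and a lower number holds for 3-chlorophenyl and 4-bromophenyl, while compound 4 goes against it. No measurement at hand accounts for this difference between the aromatic groups.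

As far as these compounds go, what an unsubstituted phenyl would give remains open, so the part played by the chlorine or bromine cannot yet be separated from that of the phenyl ring itself. Also open, from the compounds shown here alone, is how a phenyl carrying an amine or a carboxylic acid, or a longer carbon chain in place of tert-butyl, would compare on this aromatic nitrogen.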